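A few compounds are considered here, and "the series" means these few. Any claim that something is new, unique, unknown or untested is made for them only; others in the source may bear on it.

The measured compounds:
compound 1, `O=c1cc(/C=N\c2ccc(O)cc2)c2ccc(OCc3ccccc3)cc2o1`, 525000 nM
compound 2, `Nc1ccccc1/N=C\c1cc(=O)oc2cc(OCc3ccccc3)ccc12`, 217000 nM
compound 3, `N/N=C\c1cc(=O)oc2cc(OCc3ccccc3)ccc12`, 131000 nM

In a functional assay, read by spectrophotometry, with a stated time of 5 min (a lower number here means a stronger inhibitor, a higher number a weaker inhibitor), compound 1 stands highest of the three, so it is the weakest inhibitor shown. Both steps away from it run downward: a 2.4-fold lower number from compound 1 to compound 2 (0.38 log units; beyond the scatter) and a 4.0-fold lower number from compound 1 to compound 3 (0.60 log units; beyond the scatter). Between the other two, a 1.7-fold lower number from compound 2 to compound 3 (0.22 log units; within the scatter).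

Compound 4, `O=c1cc(/C=N\c2ccc(O)cc2)c2c(OCc3ccccc3)cc(OCc3ccccc3)cc2o1`, differs from compound 1 by benzyloxy in place of hydrogen on an aromatic carbon. Every measured step alters only the group on the double-bonded nitrogen, so none of them bears on this change to the core. With nothing to go on, no step beyond the scatter is expected, and the estimate for compound 4 amounts to no change at the digits printed from compound 1 to compound 4 (within the scatter). Compound 4 is therefore expected to give about 525000 nM, within a range of 180000 nM to 1500000 nM.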

Compound 4, half-maximal inhibitory concentration: 249000 nM
For compound 4 the middle estimate is 2.1-fold (0.32 log units) above the measured one, and the stated range covers the measured number.
By their numbers in this assay, from the lowest: compounds 3, 2 and 4 (each within the scatter of the next); then compound 1.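

In this assay, benzyloxy in place of hydrogen on an aromatic carbon, ortho to a fused ring, gives a 2.1-fold lower number from compound 1 to compound 4 (0.32 log units; beyond the scatter). This is the only step shown that changes the core rather than the group on the double-bonded nitrogen, and it shows that the core of compound 1 accepts this added benzyloxy at this position with a modest gain in inhibition. Nothing available explains this step. Going by these compounds, it remains open whether methoxy or hydroxyl at this position would lower the number too, and whether benzyloxy here would do the same in compound 2 or compound 3.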